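Swapping a piperidine for an isopropylpiperazine: stability expectation

The compounds below may be only part of what the source reports. "The series", "measured", "known", "first", "only" and "open" are said of these compounds alone.

Measured compounds:
- compound 1, `CN1CCN(CCCN(C[C@H]2Cc3ccccc3CN2)[C@H]2CCCc3cccnc32)CC1`: 53%
- compound 2, `c1ccc2c(c1)CN[C@@H](CN(CC1CCNCC1)[C@H]1CCCc3cccnc31)C2`: 13%
- compound 3, `c1ccc2c(c1)CN[C@@H](CN(CC[C@H]1CCCNC1)[C@H]1CCCc3cccnc31)C2`: 56%

In an ADME assay on microsomes from liver (Mus musculus) for metabolic stability, read by LC-MS, with a stated time of 10 min, tested at 0.5 uM (a lower number here means that less of the compound is left, a higher number that more of the compound is left), compound 3 gives 56%. Compound 3 and compound 1 cannot be told apart on these numbers, since a number 3 percentage points higher from compound 1 to compound 3 (within the scatter). Compound 2 sits well below both: a number 40 percentage points lower from compound 1 to compound 2 (beyond the scatter), and a number 43 percentage points higher from compound 2 to compound 3 (beyond the scatter).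

Compound 4, `CC(C)N1CCN(CCCN(C[C@H]2Cc3ccccc3CN2)[C@H]2CCCc3cccnc32)CC1`, has not yet been measured in this assay. It differs from compound 3 in one place: (4-isopropylpiperazin-1-yl)methyl in place of piperidin-3-yl on a saturated chain carbon, two bonds along the chain from an amine nitrogen.

Going by the values given here, the step that bears on this change is the one from compound 1 to compound 3, where a methylpiperazinylmethyl group was replaced by a piperidin-3-yl group with no shift beyond the scatter. Among the compounds with values here, compound 4 returns to a piperazine of that kind, now carrying an isopropyl group instead of a methyl group, and no measured step shows what that isopropyl group does. The expected step is therefore small: compound 4 is estimated to come out near compound 3, with a number 8 percentage points lower from compound 3 to compound 4 (within the scatter), and is expected to give 48%, within a range from 28% to 68%.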

Compound 4, percent of the compound remaining: 58%
For compound 4 the middle estimate is 10 percentage points below the measured one; the measured number falls inside the stated range.
By their numbers in this assay, from the lowest: compound 2; then compounds 1, 3 and 4 (each within the scatter of the next).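

Isopropyl in place of methyl on an amine nitrogen in a ring makes no difference that can be told apart in this assay, with a number 5 percentage points higher from compound 1 to compound 4 (within the scatter), so this piperazine nitrogen accepts either group without a detectable change in this read-out. The step from piperidin-3-yl to (4-isopropylpiperazin-1-yl)methyl also stays small, with a number 2 percentage points higher from compound 3 to compound 4 (within the scatter), which puts the isopropylpiperazine level with both earlier compounds at this position. Set against the piperidin-4-yl group, the 2-(4-isopropylpiperazin-1-yl)ethyl group gives a number 45 percentage points higher from compound 2 to compound 4 (beyond the scatter), leaving compound 2 as the only one of the four clearly apart from the rest.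

Nothing shown here accounts for why these groups behave alike or why compound 2 stands apart. Still open, as far as these compounds go, is whether a tert-butyl or cyclopropyl group on that ring nitrogen, or a longer chain to the piperazine, would hold this level.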